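The compounds below may be only part of what the source reports. "The series", "measured", "known", "first", "only" and "open" are said of these compounds alone.

Measured compounds:
- compound 1, `N#Cc1ccccc1CN1CCc2c(sc(NC(=O)c3ccccc3Cl)c2C(N)=O)C1`, 10400 nM
- compound 2, `NC(=O)c1c(NC(=O)c2ccccc2I)sc2c1CCN(C(=S)Nc1ccccc1Cl)C2`, 8560 nM
- compound 3, `Cc1ccc(C(=O)Nc2sc3c(c2C(N)=O)CCN(C(=O)Nc2ccccc2Cl)C3)cc1`, 14600 nM

All three were tested in a functional assay on HL-60 cells (Homo sapiens) for antiproliferative activity, with a stated time of 24 h; a lower number here means a stronger inhibitor, a higher number a weaker inhibitor. Compound 2 gives the lowest of the three numbers, but the gaps to compound 1 and to compound 3 both lie within the usual scatter of repeated measurements, so the three cannot be told apart on these numbers. Compound 4, `NC(=O)c1c(NC(=O)c2ccncn2)sc2c1CCN(C(=S)Nc1ccccc1Cl)C2`, has not yet been measured. Its structure differs from compound 2 in one place: pyrimidin-4-yl in place of 2-iodophenyl on a carbonyl carbon. For the measured compounds named here, since no step between two measured compounds covers this change, its size in this assay can only be guessed. The expectation is a step from compound 2 to compound 4 that stays close to the scatter, if anything toward a higher number, which the estimated step of a 1.4-fold higher number from compound 2 to compound 4 (0.15 log units; within the scatter) expresses. For compound 4 the estimated value in this assay is 12000 nM, with a range from 4000 nM to 40000 nM.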

Compound 4, half-maximal inhibitory concentration: 34600 nM
Compound 4: the middle estimate sits 2.9-fold (0.46 log units) below what was measured; the range from low to high includes it.
By their numbers in this assay, from the lowest: compounds 2, 1 and 3 (each within the scatter of the next); then compound 4.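

Among the compounds so far, the numbers could not be told apart, but this position on the carbonyl carbon does make a difference in this assay: pyrimidin-4-yl in place of 2-iodophenyl gives a 4.0-fold higher number from compound 2 to compound 4 (0.61 log units; beyond the scatter) and so the first step beyond the scatter. The step is modest, and the swap changes several things at once, since the iodine leaves and a ring with hetero atoms that count as hydrogen-bond acceptors enters. No measurement here explains the loss of activity.

The compounds shown leave open whether losing the iodine or gaining the ring nitrogens accounts for the step, which an unsubstituted phenyl or a pyridine ring at this position could help separate. They also leave open whether the same change would give a similar step on a core other than that of compound 2.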